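Quinoxalin-2-yl in Place of Pyridin-3-yl: An Expected Partial Recovery

The compounds below may be only part of what the source reports. "The series", "measured", "known", "first", "only" and "open" are said of these compounds alone.

Measured so far:
Compound 1 `Cc1nc(C(F)(F)F)ccc1C(=O)Nc1ccc(Cl)c(-c2cc3ccccc3[nH]2)c1` gives 500 nM in an assay on C3H 10T1/2 cells for inhibition of Sonic hedgehog protein (Mus musculus), read by a luciferase reporter; a higher number here means a weaker inhibitor, a lower number a stronger inhibitor.
Compound 2 `Cc1nc(C(F)(F)F)ccc1C(=O)Nc1ccc(Cl)c(-c2cccnc2)c1` gives 10000 nM in this assay.

Among the compounds with values here, compound 2 stands at the highest of the two numbers; its only neighbour is compound 1, and the single measured step, a 20-fold higher number from compound 1 to compound 2 (1.30 log units; beyond the scatter), is large and well beyond the scatter. It shows that exchanging the two-ring 1H-indol-2-yl for the single-ring pyridin-3-yl costs a great deal in this assay.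

Compound 3 `Cc1nc(C(F)(F)F)ccc1C(=O)Nc1ccc(Cl)c(-c2cnc3ccccc3n2)c1` differs from compound 2 in one place: quinoxalin-2-yl in place of pyridin-3-yl on an aromatic carbon. This change once more puts a two-ring group at the position ortho to the chloro group, though the entering group carries two hydrogen-bond acceptors and no donor, unlike the group of compound 1. Within the data shown here, only the step from compound 1 to compound 2 bears on it, and it bears on it only in part, since the ring that returns is not the same. A step in this assay is therefore expected in the direction of a lower number, smaller than the step that was lost, estimated as a 4.0-fold lower number from compound 2 to compound 3 (0.60 log units; beyond the scatter). Compound 3 is thus expected to give about 2500 nM, within a range of 600 nM to 10000 nM.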

Compound 3, half-maximal inhibitory concentration: 52 nM
Compound 3: the middle estimate sits 48-fold (1.68 log units) above what was measured, and the stated range ends above it.
By their numbers in this assay, from the lowest: compound 3; then compound 1; then compound 2.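

In this assay, quinoxalin-2-yl in place of pyridin-3-yl gives a 190-fold lower number from compound 2 to compound 3 (2.28 log units; beyond the scatter), a change that more than makes up for the loss seen in a 20-fold higher number from compound 1 to compound 2 (1.30 log units; beyond the scatter). Nor does the new group merely match the earlier two-ring group: quinoxalin-2-yl in place of 1H-indol-2-yl gives a 9.6-fold lower number from compound 1 to compound 3 (0.98 log units; beyond the scatter), so on this aromatic carbon, ortho to a chloro group, a low number does not depend on a hydrogen-bond donor in the group, and the two two-ring groups are not interchangeable. Nothing available explains why this change has so large an effect in this assay.

The compounds shown do not separate the contribution of the second ring from that of the ring nitrogens, since quinoxalin-2-yl differs from pyridin-3-yl in both, and a naphthalen-2-yl group, with carbon-only rings, or a quinolin-3-yl group, with a single ring nitrogen, would bear directly on that question. They also leave open how far the quinoxalin-2-yl group itself can be altered, for instance by a methoxy group or an amine on its carbon-only ring, without losing the low number of compound 3.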